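Removing the aromatic chloro from compound 1

This account rests on a few compounds, and the source may have more. Where it says the series, first, only, none or still open, it means among the compounds named here.

Compound 1 `CCC1(CCCCN2CCN(c3cccc(Cl)c3)CC2)C(=O)Nc2ccccc21` is measured in a functional assay on the whole organism (strain Wistar) with Rattus norvegicus as the target, with a stated time of 5 min; a lower number here means that less compound is needed, a higher number that more compound is needed for the effect. In this assay compound 1 gives > 20 mg/kg, which is a limit of the assay and not a number. Compound 2 `CCC1(CCCCN2CCN(c3cccc(Cl)c3)CC2)C(=O)Nc2ccc(Cl)cc21` gives > 20 mg/kg in this assay, likewise a limit. Compound 3 `O=C1Nc2ccccc2C1CCCCN1CCN(c2cccc(Cl)c2)CC1` gives < 5 mg/kg in this assay, again a limit rather than a number. Among the three values shown, two sit at the limit of > 20 mg/kg in this assay, at which 2 of the 3 values shown sit, and one at the limit of < 5 mg/kg in this assay, at which 1 of the 3 values shown sits, so compound 1 stands with a limit only, together with compound 2. The step that the two limits leave unreadable from compound 1 to compound 2 cannot be read from the two limits. The step of an at least 4.0-fold lower number from compound 1 to compound 3 (0.60 log units; beyond the scatter) concerns the ethyl on the saturated ring carbon, not the aromatic chloro.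

Compound 4 `CCC1(CCCCN2CCN(c3ccccc3)CC2)C(=O)Nc2ccccc21` differs from compound 1 by hydrogen in place of chloro on an aromatic carbon. For the measured compounds named here, no measured step bears directly on this change; the only step that touches a chloro, a step that the two limits leave unreadable from compound 1 to compound 2, is unreadable. Hence no step beyond the scatter is expected in this assay. Compound 4 is therefore estimated at 30 mg/kg, with a range from 12 mg/kg to 80 mg/kg, and is most likely reported again as a limit. The expected step is a step that the limit leaves unreadable from compound 1 to compound 4.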

Compound 4, minimum effective dose: 10 mg/kg
Estimate against measurement, compound 4: 3.0-fold (0.48 log units) above; measured number outside the range, below it.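

In this assay, the change from 3-chlorophenyl to phenyl gives an at least 2.0-fold lower number from compound 1 to compound 4 (0.30 log units; that floor lies within the scatter), so removing the chloro cannot yet be called a change beyond the scatter. The step remains only a floor because compound 1 stands at a limit of the assay: the limit of > 20 mg/kg in this assay, at which 2 of the 4 values shown sit. Compound 4 is nonetheless the first compound shown that keeps the ethyl group and gives a number rather than a limit, whereas compound 1 and compound 2 give limits only.

The compounds shown leave open how large the step from 3-chlorophenyl to phenyl really is, and whether it would carry over to the core of compound 3, which lacks the ethyl group. They also leave open how a fluoro or a methoxy group at this aromatic carbon would compare with chloro and hydrogen.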